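Does a longer chain cost activity here?

The source may hold more compounds than are shown below. What is called first, only, known or untested is meant among the compounds shown, and "the series" means these compounds.

In a functional assay on HCT-116 cells (Homo sapiens) for inhibition, read by MTT assay, with a stated time of 48 h (on this read-out higher numbers stand for weaker inhibition and lower numbers for stronger inhibition), the measured compounds read:
compound 1 `COc1ccc(N(C)c2nc(C)nc3ccccc23)cc1OCCC[Se]C#N` gives 852 nM
compound 2 `COc1ccc(N(C)c2nc(C)nc3ccccc23)cc1OCCCCCC[Se]C#N` gives 6180 nM
compound 3 `COc1ccc(N(C)c2nc(C)nc3ccccc23)cc1C(=O)OCCC[Se]C#N` gives 720 nM

Compound 3 and compound 1 cannot be told apart (a 1.2-fold lower number from compound 1 to compound 3 (0.07 log units; within the scatter)), and both sit well under compound 2 (an 8.6-fold lower number from compound 2 to compound 3 (0.93 log units; beyond the scatter)). The next compound, compound 4 `COc1ccc(N(C)c2nc(C)nc3ccccc23)cc1C(=O)OCCCCC[Se]C#N`, keeps the carbonyl of compound 3 but carries a longer chain: a group of 5 heavy atoms (3 carbon, 1 nitrogen, 1 selenium; no ring) in place of a group of 3 heavy atoms (1 carbon, 1 nitrogen, 1 selenium; no ring), on a saturated chain carbon, three bonds along the chain from an oxygen next to a carbonyl group is the whole change. Among the compounds with values here, the closest guide is the one measured step that only lengthens a chain (a 7.3-fold higher number from compound 1 to compound 2 (0.86 log units; beyond the scatter)), and it points to weaker inhibition. That chain hangs from an oxygen on an aromatic ring rather than from an oxygen next to a carbonyl group, so it is a single, imperfect precedent. Compound 4 also gains less chain than that step added, so a smaller rise in the same direction is expected in this assay. The expected step is this (a 2.8-fold higher number from compound 3 to compound 4 (0.44 log units; beyond the scatter)). Compound 4 is therefore expected at 2000 nM within a range of 600 nM to 7000 nM as an estimate.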

Compound 4, half-maximal inhibitory concentration: 551 nM
Estimate against measurement, compound 4: 3.6-fold (0.56 log units) above; measured number below the stated range.
By their numbers in this assay, from the lowest: compounds 4, 3 and 1 (each within the scatter of the next); then compound 2.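

Here, a longer chain costs nothing that can be detected: in this assay, replacing the group of 3 heavy atoms with the group of 5 heavy atoms gives a 1.3-fold lower number from compound 3 to compound 4 (0.12 log units; within the scatter). This position, on a saturated chain carbon, three bonds along the chain from an oxygen next to a carbonyl group, therefore accepts this extension, so the loss seen in the other series, a 7.3-fold higher number from compound 1 to compound 2 (0.86 log units; beyond the scatter), is not a general rule for every longer chain. Nothing available explains this difference between the two series.

Those two steps differ both in what the chain hangs from and in how much chain is added, so the compounds shown cannot separate these two factors. From the compounds shown here alone, it also remains open whether a still longer chain on the carbonyl series, or an amine at the end of the chain, would keep inhibition in this range.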